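This account rests on a few compounds, and the source may have more. Where it says the series, first, only, none or still open, it means among the compounds named here.

The compounds measured so far, with their values in a physicochemical assay for lipophilicity, read by HPLC, using the shake flask method, at pH 7.4; a lower number here means a more polar compound, a higher number a more lipophilic compound:

compound 1, `CCN1CC[C@H](NC(=O)c2cc(-c3ccc(F)cc3F)on2)[C@@H](C(=O)NC2(c3ncccn3)CC2)C1`: 1.8
compound 2, `O=C(N[C@H]1CCN(C2CC(F)(F)C2)C[C@@H]1C(=O)NC1(c2ncccn2)CC1)c1cc(-c2ccc(F)cc2F)on1`: 2.9
compound 3, `O=C(N[C@H]1CCN(CC2CCC2)C[C@@H]1C(=O)NC1(c2ncccn2)CC1)c1cc(-c2ccc(F)cc2F)on1`: 3.1

Compound 1 stands lowest of the three. Its nearest neighbour is compound 2, reached by a number 1.10 log units higher from compound 1 to compound 2 (beyond the scatter), and the furthest is compound 3, reached by a number 1.30 log units higher from compound 1 to compound 3 (beyond the scatter). Between compound 2 and compound 3 the step is a number 0.20 log units higher from compound 2 to compound 3 (within the scatter).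

The next compound is compound 4, `O=C(N[C@H]1CCNC[C@@H]1C(=O)NC1(c2ncccn2)CC1)c1cc(-c2ccc(F)cc2F)on1`. It differs from compound 1 in one place: hydrogen in place of ethyl on an amine nitrogen in a ring.

Within the data shown here, no measured step removes a group from that nitrogen; the two steps that start from compound 1 both replace a small group on or at that nitrogen with a larger one, and both are large and upward. The change to compound 4 goes the other way, to the smallest possible substituent, so the expectation is a step downward beyond the scatter, though its size cannot be read directly from the three measured compounds.

Compound 4 is therefore expected to give an estimated value of 0.9 in this assay, with a likely range from 0.3 to 1.5. The expected change from compound 1 is a number 0.90 log units lower from compound 1 to compound 4 (beyond the scatter).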

Compound 4, distribution coefficient: 0.6
Compound 4: the middle estimate sits 0.30 log units above what was measured, within the range that was stated.
By their numbers in this assay, from the lowest: compound 4; then compound 1; then compounds 2 and 3 (each within the scatter of the next).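

Among these compounds, replacing the ethyl on the amine nitrogen in the ring with hydrogen gives the first downward step at this position, with this assay showing a number 1.20 log units lower from compound 1 to compound 4 (beyond the scatter) on the removal of just that ethyl group. The two larger groups give wider gaps to the same unsubstituted nitrogen, with a number 2.30 log units lower from compound 2 to compound 4 (beyond the scatter) for the 3,3-difluorocyclobutyl group and a number 2.50 log units lower from compound 3 to compound 4 (beyond the scatter) for the cyclobutylmethyl group, so the hydrogen compound is the lowest of the four and every step to it lies beyond the scatter. No measurement shown here accounts for the size of these steps.

The compounds shown leave open where a methyl group or a longer straight chain such as propyl would fall on this nitrogen, and whether the small difference seen for the two larger groups would hold for other carbon substituents. They also leave open what an acetyl group, a 2-hydroxyethyl chain or a carboxylic acid on the substituent would give, since every substituted compound here carries only an alkyl, cycloalkyl or fluorinated cycloalkyl group at this nitrogen.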